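From Morpholine to Dimethylamino on the Sulfonyl Sulfur

The source may hold more compounds than are shown below. What is called first, only, known or untested is meant among the compounds shown, and "the series" means these compounds.

Of the compounds shown here, two sharing one core have been measured in a physicochemical assay for lipophilicity, measured as octanol-water partition, at pH 7.4; on this read-out higher numbers stand for higher lipophilicity and lower numbers for lower lipophilicity. Compound 1 `Cc1ccc2[nH]c(C(=O)N[C@H]3CCN(S(=O)(=O)N4CCCCC4)C[C@@H]3C(=O)NCCN(C)C)cc2c1` gives 2.3. Compound 2 `Cc1ccc2[nH]c(C(=O)N[C@H]3CCN(S(=O)(=O)N4CCOCC4)C[C@@H]3C(=O)NCCN(C)C)cc2c1` gives 1, the lower of the two numbers. Compound 3 `Cc1ccc2[nH]c(C(=O)N[C@H]3CCN(S(=O)(=O)N(C)C)C[C@@H]3C(=O)NCCN(C)C)cc2c1` has yet to be measured and differs from compound 2 in one place: dimethylamino in place of morpholin-4-yl on a sulfonyl sulfur. Here, dimethylamino stands in place of morpholin-4-yl on a sulfonyl sulfur. Among the measured compounds shown here, only one measured step bears on this change: a number 1.30 log units lower from compound 1 to compound 2 (beyond the scatter), a large step beyond the scatter, with morpholin-4-yl in place of piperidin-1-yl at that same place. It involves a different pair of groups, so it offers only indirect guidance. Given that step, compound 3 is expected to lie much nearer compound 2 than compound 1, with a small upward move. The estimated step is a number 0.30 log units higher from compound 2 to compound 3 (within the scatter). For compound 3, the estimated value is 1.3, with an expected range from 0.9 to 1.8.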

Compound 3, distribution coefficient: 1.2
Beside the measured number, compound 3's estimate is 0.10 log units above it; measured number inside the range.
By their numbers in this assay, from the lowest: compounds 2 and 3 (each within the scatter of the next); then compound 1.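

In this assay the step reads a number 0.20 log units higher from compound 2 to compound 3 (within the scatter) and so leaves dimethylamino and morpholin-4-yl on the sulfonyl sulfur indistinguishable, even though dimethylamino has no ring and fewer heavy atoms. The other new comparison gives a number 1.10 log units lower from compound 1 to compound 3 (beyond the scatter) as a large step beyond the scatter, so among these three compounds only the piperidin-1-yl group of compound 1 stands apart, and the presence of a ring does not sort them, since compound 2 keeps a ring yet falls with compound 3. Nothing available here accounts for why these groups sort this way.

As far as these compounds go, it remains open whether a diethylamino group on the sulfonyl sulfur would stay with compound 3 or come closer to compound 1. From the compounds shown here alone, the place of a pyrrolidin-1-yl or a piperazin-1-yl group at the same sulfur is equally open.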